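A Ring Exchange Judged from Two Measurements

The source may report more compounds than this note shows. Statements on the series, on what has been measured and on what is new or still open speak of the compounds shown alone.

Measured compounds:
Compound 1 `Cc1cccc(/C=C2/SC(N3CCC[C@H]3C(=O)Nc3ccc4ncnc(Nc5cccc(Cl)c5)c4c3)=NC2=O)n1`: 8500 nM
Compound 2 `O=C1N=C(N2CCC[C@H]2C(=O)Nc2ccc3ncnc(Nc4cccc(Cl)c4)c3c2)S/C1=C/c1cccc(Br)n1`: 3100 nM

In a functional assay on A549 cells (Homo sapiens) for antiproliferative activity, read by MTT assay (on this read-out higher numbers stand for weaker inhibition and lower numbers for stronger inhibition), compound 1 gives 8500 nM, the higher of the two numbers shown, so it is the weaker of the measured pair. Compound 2 gives 3100 nM, and the step of a 2.7-fold lower number from compound 1 to compound 2 (0.44 log units; beyond the scatter) came from bromo in place of methyl on an aromatic carbon.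

Compound 3 `COc1ccccc1/C=C1/SC(N2CCC[C@H]2C(=O)Nc2ccc3ncnc(Nc4cccc(Cl)c4)c3c2)=NC1=O` differs from compound 1 in another way: 2-methoxyphenyl in place of 6-methylpyridin-2-yl on a double-bonded chain carbon bound to a double-bonded ring carbon. Within the data shown here, the single measured step kept the ring in place and altered only a group attached to it, whereas the step to compound 3 exchanges the whole ring. That measured step therefore serves only as a rough guide; it shows that a change at this end of the molecule moved the number by a modest amount. Nothing in the data points firmly to one direction for the new change. The number for compound 3 is expected to sit near that of compound 1, with a step of a 1.4-fold lower number from compound 1 to compound 3 (0.15 log units; within the scatter) at most modest. Compound 3 is estimated at 6000 nM, within a range of 2000 nM to 20000 nM.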

Compound 3, half-maximal inhibitory concentration: > 50000 nM
Compound 3 ended at the assay's limit; the forecaster's own chance of this, stated with the estimate: 10%; middle value at least 8.3-fold (0.92 log units) away from the limit.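

The value of compound 3 is a limit of this assay and not a number: the limit of > 50000 nM in this assay, at which 1 of the 3 values shown sits. Replacing 6-methylpyridin-2-yl with 2-methoxyphenyl gives an at least 5.8-fold higher number from compound 1 to compound 3 (0.76 log units; beyond the scatter), and replacing 6-bromopyridin-2-yl with the same group gives an at least 16-fold higher number from compound 2 to compound 3 (1.20 log units; beyond the scatter). Among these compounds, the earlier step, a 2.7-fold lower number from compound 1 to compound 2 (0.44 log units; beyond the scatter), showed only that changing a group on the ring shifts the number modestly, whereas these steps show that exchanging the whole ring at this position can weaken the compound far more, with both pyridine compounds giving measured numbers and the 2-methoxyphenyl compound reaching the limit.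

This single exchange alters two things at once, removing the ring nitrogen and adding a methoxy group, so the compounds shown cannot tell which of the two matters, and the true size of the loss stays unknown beyond the limit. A plain phenyl ring would show the effect of the ring change without the methoxy group, while a pyridin-2-yl ring carrying a methoxy group would show the effect of the methoxy group with the ring nitrogen kept.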